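A few compounds are considered here, and "the series" means these few. Any claim that something is new, unique, unknown or untested is made for them only; others in the source may bear on it.

Compound 3 `CN(C)CCn1c(=O)c(=Cc2ccc(F)c(F)c2)s/c1=C1\C(=O)Nc2cc(F)ccc21` and compound 1 `Cc1ccc2c(c1)/C(=c1/sc(=Cc3ccc(C=O)c(C=O)c3)c(=O)n1CCN(C)C)C(=O)N2` are the two members of this set with a numerical result in a functional assay on HT-29 cells (Homo sapiens) for inhibition, read by MTT assay, with a stated time of 72 h; a higher number here means a weaker inhibitor, a lower number a stronger inhibitor. Of those two numbers, compound 3 has the higher one, giving 12100 nM, while compound 1 gives 1030 nM, and the gap between them lies beyond the usual scatter of repeated measurements. Compound 2 `CCN(CC)CCCn1c(=O)c(=Cc2cc(OC)c(OC)c(OC)c2)s/c1=C1\C(=O)Nc2ccc(C)cc21` returns only a limit of the assay rather than a number, namely > 200000 nM in this assay, as noted in the record (the limit of > 200000 nM in this assay, at which 1 of the 3 values shown sits).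

Compound 4 `CCN(CC)CCCn1c(=O)c(=Cc2ccc(F)c(F)c2)s/c1=C1\C(=O)Nc2cc(F)ccc21` has not yet been measured. It differs from compound 3 in a single place: (diethylamino)methyl in place of dimethylamino on a saturated chain carbon, two bonds along the chain from an aromatic nitrogen, so that the 2-(dimethylamino)ethyl chain of compound 3 becomes a 3-(diethylamino)propyl chain in compound 4. Going by the values given here, no pair of measured compounds differs in this place alone, so the size of the step can only be guessed. Compound 2, which carries the same 3-(diethylamino)propyl chain, sits at the limit, but it also differs from compound 3 elsewhere, so its result cannot be laid on the chain alone.

The expectation for compound 4 is a step from compound 3 of a 2.5-fold higher number from compound 3 to compound 4 (0.39 log units; beyond the scatter) in this assay. Compound 4 is therefore estimated at 30000 nM, in a range from 8000 nM to 150000 nM.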

Compound 4, half-maximal inhibitory concentration: 28 nM
Estimate against measurement, compound 4: 1100-fold (3.03 log units) above; measured number outside the range, below it.
By their numbers in this assay, from the lowest: compound 4; then compound 1; then compound 3. At a limit, above all of these: compound 2.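

In this assay, the saturated chain carbon two bonds along the chain from an aromatic nitrogen proves to be a highly sensitive place: with the rest of the molecule unchanged, (diethylamino)methyl in place of dimethylamino gives a 430-fold lower number from compound 3 to compound 4 (2.64 log units; beyond the scatter). Going by these compounds alone, until this pair, no two measured compounds differed in this place alone, so the share of the result belonging to the chain could not be read apart from the other parts of the molecule; now it can, and the step is large and well beyond the scatter. Compound 2 carries the same 3-(diethylamino)propyl chain but differs from compound 4 elsewhere as well, and it stands at a limit of the assay, so this step cannot be assumed to hold on every version of the molecule: the limit of > 200000 nM in this assay, at which 1 of the 4 values shown sits.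

Chain length and the groups on the amine change together here, so the compounds shown leave open which of the two carries the step; a 2-(diethylamino)ethyl chain and a 3-(dimethylamino)propyl chain would separate them. Also open, going by these compounds, is how a ring amine such as morpholine at the end of the chain would behave in this place.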